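A few compounds are considered here, and "the series" means these few. Any claim that something is new, unique, unknown or untested is made for them only; others in the source may bear on it.

Measured compounds:
compound 1, `COc1ccc(-n2c(-c3cc(OC)c(OC)c(OC)c3)csc2=O)cc1`, 14900 nM
compound 2, `COc1ccc(-n2c(-c3cc(OC)c(OC)c(OC)c3)c(Cl)sc2=O)cc1`, 13800 nM
compound 3, `COc1ccc(-n2c(-c3cc(OC)c(OC)c(OC)c3)csc2=O)cc1[N+](=O)[O-]`, 2700 nM

These numbers come from a functional assay on CCRF-CEM cells (Homo sapiens) for antiproliferative activity, with a stated time of 72 h; on this read-out higher numbers stand for weaker inhibition and lower numbers for stronger inhibition. Compound 3 gives the lowest number of the three; the nearest is compound 2, at a gap beyond the usual scatter, and compound 1 lies a little further off. Compound 4, `COc1ccc(-n2c(-c3cc(OC)c(OC)c(OC)c3)c(Cl)sc2=O)cc1[N+](=O)[O-]`, has not yet been measured. It differs from compound 3 in one place: chloro in place of hydrogen on an aromatic carbon. The same change has been measured once already, a 1.1-fold lower number from compound 1 to compound 2 (0.03 log units; within the scatter), a step that stays within the scatter. On that basis the expected step is a 1.0-fold lower number from compound 3 to compound 4 (0.02 log units; within the scatter), with no movement beyond the scatter in either direction. Compound 4 is therefore estimated at 2600 nM, with a range from 1200 nM to 6000 nM.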

Compound 4, half-maximal inhibitory concentration: > 20000 nM
Compound 4 gave a limit, no number; the forecaster's own chance of this, stated with the estimate: 2%; middle value at least 7.6-fold (0.88 log units) from the limit.
By their numbers in this assay, from the lowest: compound 3; then compounds 2 and 1 (each within the scatter of the next). At a limit, above all of these: compound 4.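

In this assay, compound 4 gave only a limit, > 20000 nM. With the nitro group present, chloro next to the ring sulfur gives an at least 7.4-fold higher number from compound 3 to compound 4 (0.86 log units; beyond the scatter), so the outcome of this change depends on the rest of the molecule: the same change on two cores in this assay, a 1.1-fold lower number (0.03 log units; within the scatter) from compound 1 to compound 2 and an at least 7.4-fold higher number (0.86 log units; beyond the scatter) from compound 3 to compound 4, at least 7.9-fold (0.90 log units) apart, beyond the scatter of two such steps The nitro change also depends on its core, giving an at least 1.4-fold higher number from compound 2 to compound 4 (0.16 log units; that floor lies within the scatter) when chloro is present: the same change on two cores in this assay, a 5.5-fold lower number (0.74 log units; beyond the scatter) from compound 1 to compound 3 and an at least 1.4-fold higher number (0.16 log units; that floor lies within the scatter) from compound 2 to compound 4, at least 7.9-fold (0.90 log units) apart, beyond the scatter of two such steps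

Going by these compounds, whether a methyl group or an amine at this position would behave like chloro remains open. So does the true size of both steps to compound 4, which only a number rather than a limit could give.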